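From isopropyl to methyl at the limit of the assay

This account rests on a few compounds, and the source may have more. Where it says the series, first, only, none or still open, it means among the compounds named here.

Two compounds have readings so far. In a functional assay on CUTLL1 cells (Homo sapiens) for inhibition, read by resazurin assay, with a stated time of 48 h, in the presence of a further agent that is not named here (a higher number here means that more compound is needed for the effect, a lower number that less compound is needed), compound 1 (`Nc1ncc(-c2ccncc2Br)c(C2CC2)n1`) gives 75000 nM. In this assay compound 2 (`CC(C)c1nc(N)ncc1-c1ccncc1`) gives > 100000 nM, which is a limit of the assay and not a number. As far as these compounds go, compound 2 thus stands at the limit of > 100000 nM in this assay, at which 1 of the 2 values shown sits, and its exact position is unknown.

Compound 3 (`Cc1nc(N)ncc1-c1ccncc1`) carries methyl in place of isopropyl on an aromatic carbon. Among the compounds with values here, no measured pair in this set isolates a change at this place, so the expectation rests only on the two readings. Compound 1 at 75000 nM shows that a number can be obtained in this high range of concentrations, and it gives no sign of a much lower reading for this set. The expected step is a number no higher from compound 2 to compound 3 (the limit leaves the size open), which means no change beyond the scatter in this assay, with neither direction favoured. A reading that is again only a limit is considered more likely than a number. The estimate for compound 3 is 100000 nM, with an expected range from 50000 nM to 200000 nM.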

Compound 3, half-maximal effective concentration: > 100000 nM
Compound 3 gave a limit, no number (the forecaster's own chance of this, stated with the estimate: 70%); the middle value sits exactly at the limit.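

No step can be read between compound 2 and compound 3, which differ by methyl in place of isopropyl on an aromatic carbon, because each reading is only a limit of the assay and not a number: the limit of > 100000 nM in this assay, at which 2 of the 3 values shown sit.

The compounds shown leave open where either compound truly stands and whether this change alters the reading at all.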